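The source may report more compounds than this note shows. Statements on the series, on what has been measured and on what is new or still open speak of the compounds shown alone.

Compound 1 `COc1ccc2occ(CSC(=S)N(C(C)C)C(C)C)c(=O)c2c1`: 8900 nM
Compound 2 `COc1ccc2oc(CSC(=S)N3CCOCC3)cc(=O)c2c1`: 3000 nM
Compound 3 `COc1ccc2oc(CSC(=S)N(C(C)C)C(C)C)cc(=O)c2c1`: 7600 nM

All three were tested in a functional assay on HEp-2 cells (Homo sapiens) for antiproliferative activity, read by MTT assay, with a stated time of 72 h; a lower number here means a stronger inhibitor, a higher number a weaker inhibitor. Compound 1 gives 8900 nM, and compound 3 gives 7600 nM; these two numbers lie within the scatter of each other. Compound 2 gives 3000 nM. The change from compound 3 to compound 2, (morpholin-4-yl in place of diisopropylamino on a thiocarbonyl carbon), made a 2.5-fold lower number from compound 3 to compound 2 (0.40 log units; beyond the scatter). Compound 4 `COc1ccc2occ(CSC(=S)N3CCOCC3)c(=O)c2c1` is not yet measured; it arises from compound 1 by the same change, (morpholin-4-yl in place of diisopropylamino on a thiocarbonyl carbon), at the same place. The cores of compound 1 and compound 3 hold the same atoms joined differently, and the difference between the two cores is not broken down here. Among the compounds with values here, the change is expected to move the number by about as much as before, since the one precedent is a 2.5-fold lower number from compound 3 to compound 2 (0.40 log units; beyond the scatter), giving an expected 2.5-fold lower number from compound 1 to compound 4 (0.39 log units; beyond the scatter). Compound 4 is therefore estimated at 3600 nM, likely between 1500 nM and 9000 nM.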

Compound 4, half-maximal inhibitory concentration: 4800 nM
Compound 4: middle estimate off by 1.3-fold (0.12 log units), on the low side, within the range that was stated.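

In this assay, putting morpholin-4-yl in place of diisopropylamino gives a 1.9-fold lower number from compound 1 to compound 4 (0.27 log units; within the scatter), a step that, taken alone, cannot be told apart from the scatter of repeated measurements. Set beside the earlier step, it points the same way and does not differ in size beyond that scatter: the same change on two cores in this assay, a 2.5-fold lower number (0.40 log units; beyond the scatter) from compound 3 to compound 2 and a 1.9-fold lower number (0.27 log units; within the scatter) from compound 1 to compound 4, 1.4-fold (0.14 log units) apart, within the scatter of two such steps. The change therefore carries over between these two cores, but two pairs set no rule for other cores and do not show why the number moves.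

The compounds shown leave open how other amines on the thiocarbonyl carbon, such as dimethylamino, piperidin-1-yl or piperazin-1-yl, would behave. They also leave open whether the step would hold in other cell lines.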